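This account rests on a few compounds, and the source may have more. Where it says the series, first, only, none or still open, it means among the compounds named here.

Measured compounds in a functional assay on NCI/ADR cells (Homo sapiens) for cytotoxicity, read by sulforhodamine B assay; a lower number here means a stronger inhibitor of growth, a higher number a weaker inhibitor of growth:
- compound 1, `CC1=CC[C@@H]([C@@](C)(O)CCCC(C)(C)NC=S)CC1`, gives 16700 nM
- compound 2, `CC1=CC[C@@H]([C@@](C)(O)CCCC(C)(C)NC(=S)N/N=C\c2ccc(N(C)C)cc2)CC1`, gives 25200 nM
- compound 3, `CC1=CC[C@@H]([C@@](C)(O)CCCC(C)(C)NC(=S)N/N=C\c2ccc([N+](=O)[O-])cc2)CC1`, gives 12800 nM

Compound 2 has the highest of these three numbers, but its gaps to compound 1 and to compound 3 both stay within the scatter, so no real order among them can be claimed. Compound 4, `CC1=CC[C@@H]([C@@](C)(O)CCCC(C)(C)NC(=S)N/N=C\c2ccccc2Cl)CC1`, differs from compound 2 by 2-chlorophenyl in place of 4-(dimethylamino)phenyl on a carbon with a double bond to nitrogen. Among the compounds with values here, the only measured step touching this position is a 2.0-fold lower number from compound 2 to compound 3 (0.29 log units; within the scatter), a change that stayed within the scatter. On that single precedent no shift beyond the scatter is expected in this assay for compound 4, so the expected step is a 1.4-fold lower number from compound 2 to compound 4 (0.15 log units; within the scatter). Compound 4 is therefore estimated at 18000 nM, with a range from 8000 nM to 45000 nM.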

Compound 4, concentration for 50% growth inhibition: > 100000 nM
Compound 4: no number, only a limit; the forecaster's own chance of this, stated with the estimate: 5%; middle value at least 5.5-fold (0.74 log units) from the limit.
By their numbers in this assay, from the lowest: compounds 3, 1 and 2 (each within the scatter of the next). At a limit, above all of these: compound 4.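

Changing the ring on the carbon with a double bond to nitrogen can matter after all: swapping 4-(dimethylamino)phenyl for 4-nitrophenyl stayed within the scatter, but 2-chlorophenyl gives an at least 3.9-fold higher number from compound 2 to compound 4 (0.59 log units; beyond the scatter) and an at least 7.8-fold higher number from compound 3 to compound 4 (0.89 log units; beyond the scatter). In this assay compound 4 gives > 100000 nM, which is a limit and not a number.

Still open, on these data alone, is whether this step follows the chlorine itself or its place on the ring. A 4-chlorophenyl or a plain phenyl group at this position would help separate those two readings.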